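The source may hold more compounds than are shown below. What is called first, only, known or untested is meant among the compounds shown, and "the series" means these compounds.

Working notes on the series. The shared core appears in compound 1 `C=CC1=C(C(=O)NC(C)(C)C)C(c2ccc(OC)cc2)OC1`, compound 2 `C=CC1=C(C(=O)Nc2ccccc2OC)C(c2ccc(Cl)c(Cl)c2)OC1` and compound 3 `C=CC1=C(C(=O)NC(C)(C)C)C(c2ccc(F)cc2)OC1`, the three differing only in the amide substituent and the aryl ring. In a functional assay on HeLa cells (Homo sapiens) for cytotoxicity, read by MTT assay, with a stated time of 24 h (a higher number here means a weaker inhibitor, a lower number a stronger inhibitor), compound 1 reaches only a limit of the assay, > 100000 nM. In this assay compound 2 likewise gives a limit and no number, > 100000 nM. In this assay compound 3 also sits at a limit, > 100000 nM. Among the measured compounds shown here, the one single-point step available, a step that the two limits leave unreadable from compound 1 to compound 3, runs between two limits, so its size cannot be read. Compound 3 therefore stands exactly where the whole set stands: at the limit of > 100000 nM in this assay, at which 3 of the 3 values shown sit, with no measured number that would separate it from the others.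

Compound 4 `C=CC1=C(C(=O)NCc2ccccc2)C(c2ccc(F)cc2)OC1` differs from compound 3 by benzyl in place of tert-butyl on an amide-type nitrogen. For the measured compounds named here, no measured pair varies the substituent on the amide nitrogen alone, and the only step that exists gives no readable size. With every value sitting at the limit, the step from compound 3 to compound 4 in this assay is expected to be a step that the limit leaves unreadable from compound 3 to compound 4, that is, nothing beyond the scatter that could be resolved. Compound 4 is accordingly estimated at 150000 nM, within 50000 nM to 500000 nM, most likely reported again as a limit.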

Compound 4, half-maximal inhibitory concentration: > 100000 nM
Compound 4: no number, only a limit; the forecaster's own chance of this, stated with the estimate: 80%; the middle value is on the limit's open side.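

In this assay compound 3 and compound 4 each give only a limit of the assay, so no new step can be read between them. The compounds shown leave open whether any amide substituent or aryl ring on the shared core gives a measured number in this assay rather than a limit, and how far either place changes the read-out.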